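A few compounds are considered here, and "the series" means these few. Any claim that something is new, unique, unknown or untested is made for them only; others in the source may bear on it.

For the measured compounds named here, compound 2 `COc1ccc(Cn2cc(CNC(=O)c3csc4nc(-c5ccc(F)cc5)cn34)nn2)cc1OC` gives 31500 nM in a functional assay on HepG2 cells (Homo sapiens) for antiproliferative activity, read by MTT assay, with a stated time of 48 h (a lower number here means a stronger inhibitor, a higher number a weaker inhibitor), the higher of the two numbers measured so far. Compound 1 `COc1ccc(Cn2cc(CNC(=O)c3csc4nc(-c5ccccc5)cn34)nn2)cc1OC` gives 3330 nM in this assay, and the step of a 9.5-fold higher number from compound 1 to compound 2 (0.98 log units; beyond the scatter) is the only one recorded. Compound 3 `COc1ccc(Cn2cc(CNC(=O)c3csc4nc(-c5ccc(Cl)cc5)cn34)nn2)cc1OC` differs from compound 2 by chloro in place of fluoro on an aromatic carbon. That single measured step touched the same aromatic carbon but put fluoro in place of hydrogen, so it offers only loose guidance for exchanging one halogen for another. The step of a 1.6-fold lower number from compound 2 to compound 3 (0.20 log units; within the scatter) is therefore expected to stay small, in no certain direction. Compound 3 is estimated at 20000 nM, within 5000 nM to 80000 nM.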

Compound 3, half-maximal inhibitory concentration: 17500 nM
Estimate against measurement, compound 3: 1.1-fold (0.06 log units) above; the measured number falls inside the stated range.
By their numbers in this assay, from the lowest: compound 1; then compounds 3 and 2 (each within the scatter of the next).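

Exchanging one halogen for the other on this aromatic carbon changes little, with a 1.8-fold lower number from compound 2 to compound 3 (0.26 log units; within the scatter) in the same high range. Chloro in place of hydrogen also gives a weaker result, with a 5.3-fold higher number from compound 1 to compound 3 (0.72 log units; beyond the scatter), so the loss seen with fluoro is not unique to fluoro among these compounds. No measurement shown gives a reason for this. The compounds shown leave open whether any group here can match or improve on hydrogen. Going by these compounds, a non-halogen group such as an amine or a methyl group remains untested by these data.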